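This account rests on a few compounds, and the source may have more. Where it says the series, first, only, none or still open, it means among the compounds named here.

Measured so far:
compound 1 `CC(C)=CCN(C)C1CCN(CCCc2c[nH]c3ccc(-n4cnnc4)cc23)CC1` — 41 nM
compound 2 `CN(Cc1ccco1)C1CCN(CCCc2c[nH]c3ccc(-n4cnnc4)cc23)CC1` — 89 nM

In an assay on CHO cells for displacement of a labelled ligand from 5-hydroxytryptamine receptor 1B (Homo sapiens) (on this read-out lower numbers stand for stronger inhibition and higher numbers for weaker inhibition), compound 2 stands at the higher of the two numbers, the step of a 2.2-fold higher number from compound 1 to compound 2 (0.34 log units; beyond the scatter) being modest. Compound 3 `c1cncc(CNC2CCN(CCCc3c[nH]c4ccc(-n5cnnc5)cc34)CC2)c1` carries ((pyridin-3-yl)methyl)amino in place of ((furan-2-yl)methyl)(methyl)amino on a saturated ring carbon. Within the data shown here, only the step from compound 1 to compound 2 bears on this, and it covered a swap of the ring on the chain carbon alone; the loss of the methyl on the amine nitrogen has no measured precedent. The change is therefore expected to be small, a 1.1-fold higher number from compound 2 to compound 3 (0.05 log units; within the scatter), likely within the scatter. Compound 3 is estimated at 100 nM, range 30 nM to 320 nM.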

Compound 3, half-maximal inhibitory concentration: 140 nM
Beside the measured number, compound 3's estimate is 1.4-fold (0.15 log units) below it, and the stated range covers the measured number.
By their numbers in this assay, from the lowest: compound 1; then compounds 2 and 3 (each within the scatter of the next).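

In this assay, exchanging ((furan-2-yl)methyl)(methyl)amino for ((pyridin-3-yl)methyl)amino on the saturated ring carbon gives a 1.6-fold higher number from compound 2 to compound 3 (0.20 log units; within the scatter) and so leaves the reading unresolved from the earlier furan compound. Against the methyl(3-methylbut-2-en-1-yl)amino group, the same entering group gives a 3.4-fold higher number from compound 1 to compound 3 (0.53 log units; beyond the scatter), a modest loss, so this position accepts a six-membered aromatic ring and a hydrogen-bond donor on the amine with no large penalty. No measured evidence accounts for either step.

The ring exchange and the missing amine methyl remain unseparated here. A ((pyridin-3-yl)methyl)(methyl)amino group would divide the two.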